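Swapping a 3-(nitrooxy)propyl Group for Hydrogen

The compounds below may be only part of what the source reports. "The series", "measured", "known", "first", "only" and "open" are said of these compounds alone.

- Compound 1 `COc1cc(/C=C/C(=O)OCCCO[N+](=O)[O-])ccc1OCCCO[N+](=O)[O-]`: > 50000 nM
- Compound 2 `COc1cc(/C=C/C(=O)Oc2ccc(OCc3c(-c4ccccc4)no[n+]3[O-])cc2)ccc1O`: > 50000 nM
- Compound 3 `COc1cc(/C=C/C(=O)OC(C)CCOc2no[n+]([O-])c2S(=O)(=O)c2ccccc2)ccc1O`: 430 nM

All three compounds were tested in a functional assay on H266 cells (Homo sapiens) for cytotoxicity, read by resazurin assay, with a stated time of 72 h; on this read-out lower numbers stand for stronger inhibition and higher numbers for weaker inhibition. Compound 1 gives > 50000 nM, which is a limit of the assay and not a number. Compound 2 gives > 50000 nM, also a limit. These two compounds make up (the limit of > 50000 nM in this assay, at which 2 of the 3 values shown sit). Among the compounds with values here, compound 3, at 430 nM, is the only one with a true number.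

Compound 4 `COc1cc(/C=C/C(=O)OCCCO[N+](=O)[O-])ccc1O` has not yet been measured. It comes from compound 1 by one change: hydrogen in place of 3-(nitrooxy)propyl on an oxygen on an aromatic ring. In words, hydrogen takes the place of 3-(nitrooxy)propyl on an oxygen on an aromatic ring, which leaves a hydroxy there.

Compound 2 has this hydroxy too and gives > 50000 nM, again a limit. Compound 3 goes against any simple reading, since it also has the hydroxy and gives 430 nM. Compound 4 still carries a 3-(nitrooxy)propyl group, as compound 1 does, so no change beyond the scatter is expected in this assay. The expected result is a number no higher from compound 1 to compound 4 (the limit leaves the size open). The estimated value for compound 4 is 50000 nM, within an expected range of 15000 nM to 100000 nM.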

Compound 4, half-maximal inhibitory concentration: 44000 nM
Estimate against measurement, compound 4: 1.1-fold (0.06 log units) above, and the stated range covers the measured number.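

In this assay, hydrogen in place of 3-(nitrooxy)propyl on an oxygen on an aromatic ring gives an at least 1.1-fold lower number from compound 1 to compound 4 (0.05 log units; that floor lies within the scatter). Compound 4 gives 44000 nM, so this oxygen now has a true number with a hydroxy on it, which compound 1 could not supply. Compound 1 has only a limit, and the real size of the step stays open because of where that limit sits: the limit of > 50000 nM in this assay, at which 2 of the 4 values shown sit.

The compounds shown leave open how a methyl or an amine-bearing chain on this same oxygen would compare with the hydroxy of compound 4. They also leave open what happens when the 3-(nitrooxy)propyl group that compound 4 keeps gives way to a plain propyl.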